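Working notes on a heteroaryl exchange in the series

This account rests on a few compounds, and the source may have more. Where it says the series, first, only, none or still open, it means among the compounds named here.

Measured so far:
compound 1, `Oc1ccccc1-c1cc(-c2cccs2)cc(-c2ccccc2O)n1`, 77.2%
compound 2, `Oc1ccccc1-c1cc(-c2ccco2)cc(-c2ccccc2O)n1`, 89.1%
compound 3, `Oc1ccccc1-c1cc(-c2ccoc2)cc(-c2ccccc2O)n1`, 1%

All three compounds share one core carrying two 2-hydroxyphenyl groups and differ only in the third aromatic group. In an assay on isolated protein for inhibition of DNA topoisomerase 1 (Homo sapiens), with a stated time of 30 min, tested at 100 uM (a higher number here means a stronger effect of the compound at the concentration tested, a lower number a weaker effect), compound 3 stands lowest of the three numbers: the steps of a number 76.2 percentage points lower from compound 1 to compound 3 (beyond the scatter) and a number 88.1 percentage points lower from compound 2 to compound 3 (beyond the scatter) both lead down to it, each beyond the scatter, while the step of a number 11.9 percentage points higher from compound 1 to compound 2 (beyond the scatter) between the two higher compounds is modest.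

The next compound is compound 4, `Oc1ccccc1-c1cc(-c2ccccn2)cc(-c2ccccc2O)n1`, reached from compound 3 by the change (pyridin-2-yl in place of furan-3-yl on an aromatic carbon).

Going by the values given here, the steps that bear on this change are a number 76.2 percentage points lower from compound 1 to compound 3 (beyond the scatter) and a number 88.1 percentage points lower from compound 2 to compound 3 (beyond the scatter): in both, replacing a group attached through the position next to its ring heteroatom by furan-3-yl removed almost the whole read-out. Pyridin-2-yl is again attached through the carbon next to its ring heteroatom, but it is a six-membered ring, for which no measured step exists, so the outcome is uncertain.

Expected is therefore a large rise, a number 54 percentage points higher from compound 3 to compound 4 (beyond the scatter), in this assay. For compound 4 the estimate is 55%, with a wide range from 5% to 95%.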

Compound 4, a percentage reported as inhibition, at one concentration (the size of the read-out at that concentration, not a potency): 0.8%
Compound 4: the middle estimate sits 54.2 percentage points above what was measured, and the stated range ends above it.
By their numbers in this assay, from the lowest: compounds 4 and 3 (each within the scatter of the next); then compound 1; then compound 2.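

In this assay, the step of a number 0.2 percentage points lower from compound 3 to compound 4 (within the scatter) puts pyridin-2-yl level with furan-3-yl on the aromatic carbon opposite the ring nitrogen, so the near-complete loss of the read-out is no longer peculiar to furan-3-yl. The steps of a number 88.3 percentage points lower from compound 2 to compound 4 (beyond the scatter) and a number 76.4 percentage points lower from compound 1 to compound 4 (beyond the scatter) show that a 2-yl attachment does not by itself preserve the read-out: furan-2-yl and thiophen-2-yl fit that description, but pyridin-2-yl goes against it, and among these four groups only the two five-membered 2-yl rings give a high number. Nothing measured here explains why these closely related aromatic groups separate so sharply.

Still open, from the compounds shown here alone, is whether the six-membered ring itself or the location of its nitrogen governs the result, a question that phenyl, pyridin-3-yl and pyridin-4-yl at this place could help settle. Also open, going by these compounds, is whether the read-out returns with a substituted furan-2-yl, such as 5-methylfuran-2-yl, or with a non-aromatic group such as an amine or a carboxylic acid.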